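Methoxy on the anilino ring of compound 1

A few compounds are considered here, and "the series" means these few. Any claim that something is new, unique, unknown or untested is made for them only; others in the source may bear on it.

Measured compounds:
- compound 1, `FC(F)(F)c1ccc(CSc2nc(Nc3ccccc3)c3ccccc3n2)cc1`: 26400 nM
- compound 2, `Cc1ccccc1Nc1nc(SCc2ccc(C(F)(F)F)cc2)nc2ccccc12`: 27500 nM
- compound 3, `FC(F)(F)c1ccc(CSc2nc(Nc3cccc(C(F)(F)F)c3)c3ccccc3n2)cc1`: 11700 nM

All three share one core and were tested in a functional assay on HGC-27 cells (Homo sapiens) for cytotoxicity, read by MTT assay, with a stated time of 72 h; a lower number here means a stronger inhibitor, a higher number a weaker inhibitor. Compound 1 gives 26400 nM, the second highest of the three numbers. Its nearest neighbour is compound 2, where the step is a 1.0-fold higher number from compound 1 to compound 2 (0.02 log units; within the scatter), so the two cannot be told apart. Compound 3 is the furthest, with a 2.3-fold lower number from compound 1 to compound 3 (0.35 log units; beyond the scatter), a modest gain.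

The new compound 4, `COc1ccc(Nc2nc(SCc3ccc(C(F)(F)F)cc3)nc3ccccc23)cc1`, differs from compound 1 by methoxy in place of hydrogen on an aromatic carbon, placed on the anilino ring.

Two measured steps change that same ring. Methyl on an aromatic carbon gave no step beyond the scatter, a 1.0-fold higher number from compound 1 to compound 2 (0.02 log units; within the scatter); trifluoromethyl gave a modest lowering, a 2.3-fold lower number from compound 1 to compound 3 (0.35 log units; beyond the scatter). Methoxy is neither group, and no measured compound carries it, so the expectation in this assay is a step of at most modest size, most likely none beyond the scatter, with a slight lean toward a lower number because a 2.3-fold lower number from compound 1 to compound 3 (0.35 log units; beyond the scatter) shows a substituent on this ring can help.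

Compound 4 is therefore estimated at 22000 nM, within 11000 nM to 45000 nM, which would mean a step of a 1.2-fold lower number from compound 1 to compound 4 (0.08 log units; within the scatter).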

Compound 4, half-maximal inhibitory concentration: 23500 nM
Beside the measured number, compound 4's estimate is 1.1-fold (0.03 log units) below it, and the stated range covers the measured number.
By their numbers in this assay, from the lowest: compounds 3, 4, 1 and 2 (each within the scatter of the next, the first and the last beyond it).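

In this assay, methoxy is the first group shown on the anilino ring para to a large group, and it brings no step that can be told from scatter, with a 1.1-fold lower number from compound 1 to compound 4 (0.05 log units; within the scatter). The comparison with the other methyl-bearing ring agrees, with a 1.2-fold lower number from compound 2 to compound 4 (0.07 log units; within the scatter), so a ring substituted with methyl or methoxy cannot be separated from the bare phenyl ring of compound 1 in these data. The step to the trifluoromethyl compound is also within the scatter, with a 2.0-fold higher number from compound 3 to compound 4 (0.30 log units; within the scatter), even though a 2.3-fold lower number from compound 1 to compound 3 (0.35 log units; beyond the scatter) lies beyond it; compound 4 therefore cannot be assigned to either side of that modest gap, and no measurement here offers an explanation for these numbers.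

As far as these compounds go, what stays open is whether a group such as an amine or a carboxylic acid at this same carbon would move the number clearly away from that of compound 1. From the compounds shown here alone, it is also open whether a longer chain such as ethoxy, or methoxy on another carbon of this ring, would do so.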